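This account rests on a few compounds, and the source may have more. Where it says the series, first, only, none or still open, it means among the compounds named here.

In a functional assay on SW480 cells (Homo sapiens) for cytotoxicity, read by MTT assay, with a stated time of 24 h (a higher number here means a weaker inhibitor, a lower number a stronger inhibitor), compound 3 `C=CC1=C(C(=O)NCCCCC)C(c2ccc(F)cc2)OC1` stands only at a limit of the assay, giving > 100000 nM. Compound 2 `C=CC1=C(C(=O)NCc2ccc(C)cc2)C(c2ccc(F)cc2)OC1` likewise sits at a limit, with > 100000 nM. Compound 1 `C=CC1=C(C(=O)NCc2ccccc2)C(c2ccc(OC)cc2)OC1`, which carries the benzyl amide and a methoxyphenyl on the shared core, gives 39500 nM. The change from compound 3 to compound 4 `C=CC1=C(C(=O)NCc2ccccc2)C(c2ccc(F)cc2)OC1` is phenyl in place of butyl on a saturated chain carbon bound to an amide-type nitrogen. Within the data shown here, only one measured step bears on this change, namely a step that the two limits leave unreadable from compound 2 to compound 3, and its size cannot be read, since both ends sit at the limit of > 100000 nM in this assay, at which 2 of the 3 values shown sit. No readable step therefore points in either direction, and the step of an at least 1.2-fold lower number from compound 3 to compound 4 (0.09 log units; that floor lies within the scatter) is expected to remain close to that limit. Among the measured compounds shown here, the value of compound 1, 39500 nM, is the only measured number for a compound with the benzyl amide, and compound 1 differs from compound 4 elsewhere on the core. Compound 4 is accordingly estimated at 80000 nM, within a range from 30000 nM to 200000 nM, and it may again be reported only as a limit.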

Compound 4, half-maximal inhibitory concentration: > 100000 nM
Compound 4 gave a limit, no number; the forecaster's own chance of this, stated with the estimate: 50%; middle value at least 1.2-fold (0.09 log units) away from the limit.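

With the benzyl amide held fixed, fluoro in place of methoxy on an aromatic carbon is an at least 2.5-fold higher number from compound 1 to compound 4 (0.40 log units; beyond the scatter) in this assay. Among these compounds, this is the first readable step, and it ties the measured number of compound 1 to the methoxy group within this pair. The steps linking compound 2, compound 3 and compound 4 cannot be read, so the change from butyl to phenyl on the saturated chain carbon shows no size in either direction, and compound 4 joins the others at the same limit: the limit of > 100000 nM in this assay, at which 3 of the 4 values shown sit.

On these data alone, whether the amide group has any effect on this measure stays open while the fluoro compounds all rest at that limit. Also open, as far as these compounds go, is whether chloro or hydroxyl on the aromatic carbon, or an amine on the amide chain, would give a number inside the range of the assay.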